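The source may hold more compounds than are shown below. What is called first, only, known or untested is meant among the compounds shown, and "the series" means these compounds.

Measured compounds: compound 1 `NNc1nonc1/C(=N/O)Nc1ccc(F)c(Br)c1`, compound 2 `NS(=O)(=O)NNc1nonc1/C(=N/O)Nc1ccc(F)c(Br)c1`, compound 3 `O=S1(=O)CC(Nc2nonc2/C(=N/O)Nc2ccc(F)c(Br)c2)C1`.

In an assay on isolated protein for inhibition of Indoleamine 2,3-dioxygenase 1 (Homo sapiens), read by fluorescence, with a stated time of 60 min (on this read-out higher numbers stand for weaker inhibition and lower numbers for stronger inhibition), compound 1 gives 108 nM, compound 2 gives 218 nM and compound 3 gives 99 nM. Compound 3 thus gives the lowest of the three numbers, though its gap to compound 1 lies within the scatter; only a 2.2-fold lower number from compound 2 to compound 3 (0.34 log units; beyond the scatter) stands beyond it. Compound 4 `N=S1(=O)CC(Nc2nonc2/C(=N/O)Nc2ccc(F)c(Br)c2)C1` differs from compound 3 by a group of 6 heavy atoms (3 carbon, 1 nitrogen, 1 oxygen, 1 sulfur; one four-membered non-aromatic ring with 1 hetero atom) in place of a group of 6 heavy atoms (3 carbon, 2 oxygen, 1 sulfur; one four-membered non-aromatic ring with 1 hetero atom), on a nitrogen on an aromatic ring. Going by the values given here, no measured step alters this part of the four-membered ring. The steps of a 1.1-fold lower number from compound 1 to compound 3 (0.04 log units; within the scatter) and a 2.0-fold higher number from compound 1 to compound 2 (0.31 log units; beyond the scatter) show that changes on this nitrogen have moved this assay at most modestly. A step within the scatter is therefore expected, a 1.0-fold higher number from compound 3 to compound 4 (0.00 log units; within the scatter). Compound 4 is estimated at 100 nM, with a range of 40 nM to 250 nM.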

Compound 4, half-maximal inhibitory concentration: 208 nM
Beside the measured number, compound 4's estimate is 2.1-fold (0.32 log units) below it; the measured number falls inside the stated range.
By their numbers in this assay, from the lowest: compounds 3, 1, 4 and 2 (each within the scatter of the next, the first and the last beyond it).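

Replacing one oxygen of the four-membered ring group with nitrogen, which adds a hydrogen-bond donor, gives a 2.1-fold higher number from compound 3 to compound 4 (0.32 log units; beyond the scatter) as a modest step, so this assay does respond to a change within that ring and not only to a change of the whole group on the nitrogen. The steps of a 1.0-fold lower number from compound 2 to compound 4 (0.02 log units; within the scatter) and a 1.9-fold higher number from compound 1 to compound 4 (0.28 log units; within the scatter) both lie within the scatter, leaving compound 4 unresolved from compound 2 and compound 1. Nothing at hand accounts for the step.

Still open, on these data alone, is whether a methyl group on the entering nitrogen would return the number towards that of compound 3. Also open, as far as these compounds go, is how a carboxylic acid or a longer chain on the four-membered ring would read.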